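Swapping a Methylphenyl Ring for a Methylfuran Ring

This account rests on a few compounds, and the source may have more. Where it says the series, first, only, none or still open, it means among the compounds named here.

compound 1 `Cc1cccc(-c2cc(-c3ccc(Cl)o3)cc(-c3ccsc3)n2)c1` — 7.5%
compound 2 `Clc1ccc(-c2cc(-c3cccnc3)nc(-c3cccs3)c2)o1` — 25.8%
compound 3 `Clc1ccc(-c2cc(-c3ccoc3)cc(-c3ccsc3)n2)cc1` — 0%

In an assay on isolated protein for inhibition of DNA topoisomerase 1 (Homo sapiens), tested at 100 uM (on this read-out higher numbers stand for a stronger effect at the one concentration tested and lower numbers for a weaker effect), compound 1 gives 7.5%, the second highest of the three numbers. Compound 3 gives 0%, a number within the scatter of compound 1, so the two cannot be told apart. Compound 2 gives 25.8%, which stands beyond the scatter above compound 1.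

Compound 4 `Cc1ccc(-c2cc(-c3ccc(Cl)o3)cc(-c3ccsc3)n2)o1` differs from compound 1 in a single place: 5-methylfuran-2-yl in place of 3-methylphenyl on an aromatic carbon. No pair of measured compounds isolates a change of this kind, so the expectation rests only on the spread of the three numbers shown. The expected step is a number 2.5 percentage points higher from compound 1 to compound 4 (within the scatter), a change no larger than the usual scatter. For compound 4 an inhibition of 10% is estimated, with a range from 0% to 30%.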

Compound 4, a percentage reported as inhibition, at one concentration (the size of the read-out at that concentration, not a potency): 9.1%
The estimate for compound 4 lay 0.9 percentage points above the measured number; the range from low to high includes it.
By their numbers in this assay, from the lowest: compounds 3, 1 and 4 (each within the scatter of the next); then compound 2.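

Putting 5-methylfuran-2-yl in place of 3-methylphenyl next to the ring nitrogen gives a number 1.6 percentage points higher from compound 1 to compound 4 (within the scatter) in this assay and so the two compounds cannot be told apart. At this position, then, a five-membered aromatic ring with one oxygen reads the same as a six-membered carbon ring, at the one concentration tested. Nothing measured here explains why the two rings read alike.

Still open, as far as these compounds go, is whether an amine or a carboxylic acid at this position would shift the number beyond the usual scatter. Also open, from the compounds shown here alone, is what the methyl group on the furan contributes.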